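A few compounds are considered here, and "the series" means these few. Any claim that something is new, unique, unknown or untested is made for them only; others in the source may bear on it.

Compound 1 `Cn1cc2c(Cl)nc(NC(=O)c3ccc(C(F)(F)F)cc3)nc2n1`: in an assay on CHO cells for displacement of a labelled ligand from adenosine receptor A1 (Homo sapiens), read by scintillation counting, with a stated time of 3 h (on this read-out higher numbers stand for weaker inhibition and lower numbers for stronger inhibition), compound 1 gives > 100000 nM, a limit of the assay.
Compound 2 `Cn1cc2c(Cl)nc(NC(=O)c3ccc(F)cc3)nc2n1`: in this assay compound 2 gives > 100000 nM, also a limit.

Compound 2 thus stands at the limit of > 100000 nM in this assay, at which 2 of the 2 values shown sit. The step that the two limits leave unreadable from compound 1 to compound 2 cannot be read, since both ends are limits. Compound 3 `CC(C)(C)Cn1cc2c(Cl)nc(NC(=O)c3ccc(F)cc3)nc2n1` differs from compound 2 by tert-butyl in place of hydrogen on a saturated chain carbon bound to an aromatic nitrogen. Among the compounds with values here, no measured step bears on this change, and the one measured step is unreadable, so nothing points in either direction. Compound 3 is expected to remain weak, with the step of an at least 1.6-fold lower number from compound 2 to compound 3 (0.22 log units; that floor lies within the scatter) expected to be small. For compound 3 the expected value is 60000 nM, between 5000 nM and 500000 nM.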

Compound 3, inhibition constant: 16500 nM
Compound 3: the middle estimate sits 3.6-fold (0.56 log units) above what was measured; measured number inside the range.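

In this assay, tert-butyl in place of hydrogen on a saturated chain carbon bound to an aromatic nitrogen gives an at least 6.0-fold lower number from compound 2 to compound 3 (0.78 log units; beyond the scatter), so this position yields a readable step, whereas the change on the aromatic carbon from compound 1 to compound 2 cannot be read. Compound 3 is the only compound shown with a number rather than a limit: the limit of > 100000 nM in this assay, at which 2 of the 3 values shown sit.

Going by these compounds, it remains open whether ethyl, a longer straight chain or an amine at this position would lower the number as neopentyl does. On these data alone, it is also open whether trifluoromethyl in place of fluoro would matter with neopentyl present.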